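Amide aryl replacement in the shared core series

The source may report more compounds than this note shows. Statements on the series, on what has been measured and on what is new or still open speak of the compounds shown alone.

Compound 1 `O=C(Nc1cccc(-n2cc(-c3ccncc3)c(-c3ccc(Cl)c(O)c3)n2)c1)Nc1ccc(Cl)c(Cl)c1`, compound 2 `COc1cc(-c2nn(-c3cccc(NC(=O)c4ccc(Cl)c(C(F)(F)F)c4)c3)cc2-c2ccncc2)ccc1Cl` and compound 3 `COc1cc(-c2nn(-c3cccc(NC(=O)c4cccc(C(F)(F)F)c4)c3)cc2-c2ccncc2)ccc1Cl` share one core and differ only in the amide-bearing side. In a functional assay on OVCAR-8 cells (Homo sapiens) for inhibition, read by sulforhodamine B assay, with a stated time of 48 h (on this read-out lower numbers stand for higher toxicity in this test and higher numbers for lower toxicity in this test), compound 1 gives > 32500 nM, which is a limit of the assay. Compound 2 gives > 32500 nM in this assay, again a limit rather than a number. Compound 3 gives > 50000 nM in this assay, also a limit. The step that the two limits leave unreadable from compound 2 to compound 3 cannot be sized, since both of its ends sit at limits, the limit of > 32500 nM in this assay, at which 2 of the 3 values shown sit, and (the limit of > 50000 nM in this assay, at which 1 of the 3 values shown sits). Compound 2 therefore stands only at a limit, and the two other values shown are limits as well.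

Compound 4 `COc1cc(-c2nn(-c3cccc(NC(=O)c4ccccc4)c3)cc2-c2ccncc2)ccc1Cl` differs from compound 2 by phenyl in place of 4-chloro-3-(trifluoromethyl)phenyl on a carbonyl carbon. Among the measured compounds shown here, the only measured step touching the amide side, from compound 2 to compound 3 with hydrogen in place of chloro, is unreadable, so no size or direction beyond the scatter can be read for this assay. Compound 4 is expected to sit at the limit again, estimated at 50000 nM with a range from 20000 nM to 100000 nM. The step that the limit leaves unreadable from compound 2 to compound 4 is accordingly expected to remain within the scatter.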

Compound 4, concentration lethal to 50% of the cells: > 100000 nM
Compound 4: a limit, no number (the forecaster's own chance of this, stated with the estimate: 85%); at least 2.0-fold (0.30 log units) between middle value and limit.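

In this assay compound 4 gives > 100000 nM, a limit of the assay. Neither step to compound 4, from compound 2 or from compound 3, can be read: both ends of each are limits. The compounds shown leave open what size any change on the amide side has on this read-out.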